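A Non-Aromatic Six-Membered Ring Replaces the Dimethoxyphenyl Group

The compounds below may be only part of what the source reports. "The series", "measured", "known", "first", "only" and "open" are said of these compounds alone.

Of the compounds shown here, two sharing one core have been measured in a functional assay on cells (Leukemia cell, Homo sapiens) for cytotoxicity, read by sulforhodamine B assay, with a stated time of 48 h; a lower number here means a stronger inhibitor of growth, a higher number a weaker inhibitor of growth. Compound 1 `COc1ccc(OC)c(-c2cc(-c3ccccc3)nn2-c2ccc(S(=O)(=O)NC(C)=O)cc2)c1` gives 7400 nM, and compound 2 `COc1ccc(OC)c(-c2cc(-c3ccc(Cl)cc3)nn2-c2ccc(S(=O)(=O)NC(C)=O)cc2)c1` gives 7450 nM. Among the measured compounds shown here, compound 1 stands at the lower of the two numbers, but the only comparable step, a 1.0-fold higher number from compound 1 to compound 2 (0.00 log units; within the scatter), is within the scatter. Compound 3 `CC(=O)NS(=O)(=O)c1ccc(-n2nc(-c3ccccc3)cc2C2=CC(=O)C=CC2=O)cc1` has not yet been measured. It differs from compound 1 by a group of 8 heavy atoms (6 carbon, 2 oxygen; one six-membered non-aromatic ring of carbon only) in place of a group of 10 heavy atoms (8 carbon, 2 oxygen; one six-membered aromatic ring of carbon only), on an aromatic carbon. For the measured compounds named here, the measured step concerns a chloro in place of hydrogen, a change unrelated to the group exchanged here, and it is within the scatter, so it does not bear on this replacement; no measured pair shows the effect of removing the 2,5-dimethoxyphenyl. The step from compound 1 to compound 3 in this assay is therefore expected to be a 1.9-fold lower number from compound 1 to compound 3 (0.27 log units; within the scatter), with a wide range. Compound 3 is estimated to give 4000 nM in this assay, between 800 nM and 20000 nM.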

Compound 3, concentration for 50% growth inhibition: 57800 nM
Compound 3: middle estimate off by 14-fold (1.16 log units), on the low side, and the stated range ends below it.
By their numbers in this assay, from the lowest: compounds 1 and 2 (each within the scatter of the next); then compound 3.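

In this assay, the place on the ring with 2 nitrogen that carries the 2,5-dimethoxyphenyl group proves sensitive to exchange: putting the non-aromatic six-membered ring there gives a 7.8-fold higher number from compound 1 to compound 3 (0.89 log units; beyond the scatter), a move toward weaker inhibition of growth. Among the compounds shown here, the earlier chloro exchange on the phenyl group, at a different place, gave only a 1.0-fold higher number from compound 1 to compound 2 (0.00 log units; within the scatter), so this is the first change that moves the number beyond the scatter. Nothing available here accounts for the loss.

The exchange removes the aromatic ring and both methoxy groups in one step, so the compounds shown cannot separate these changes from one another. As far as these compounds go, it remains open how a plain phenyl, a cyclohexyl ring or a phenyl bearing a single methoxy group would behave at this place.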